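The source may report more compounds than this note shows. Statements on the series, on what has been measured and on what is new or still open speak of the compounds shown alone.

Compound 1, `C/N=C(\NC#N)Nc1cccnc1`, gives > 50 mg/kg.
Compound 2, `CCC(C)C(C)/N=C(\NC#N)Nc1ccncc1`, gives 8 mg/kg.

Both compounds were tested in a functional assay on the whole organism (blood, strain Wistar-Okamoto) with Rattus norvegicus as the target, with a stated time of 5 days; a lower number here means that less compound is needed, a higher number that more compound is needed for the effect. For compound 1 the result is a limit of the assay rather than a number. Compound 2 therefore holds the only number in this assay, with the other result being a limit, as shown by the limit of > 50 mg/kg in this assay, at which 1 of the 2 values shown sits. Among the compounds with values here, with no two measured compounds differing in a single place, no step between measured values can be traced, and where compound 2 stands rests on its own number alone.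

Compound 3, `CC(C)(C)/N=C(\NC#N)Nc1ccncc1`, has not yet been tested. It differs from compound 2 in one place: tert-butyl in place of 1,2-dimethylbutyl on a double-bonded nitrogen. The branched chain on the double-bonded nitrogen is exchanged for a shorter, fully branched one.

Within the data shown here, with no measured step to lean on, the expected change from compound 2 to compound 3 is a modest one toward a higher dose, at the edge of the scatter, as a 1.9-fold higher number from compound 2 to compound 3 (0.27 log units; within the scatter). Compound 3 is thus expected to give about 15 mg/kg, within a range from 5 mg/kg to 50 mg/kg.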

Compound 3, minimum effective dose: 2.5 mg/kg
Compound 3: middle estimate off by 6.0-fold (0.78 log units), on the high side; the measured number lies below the stated range.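

Within the data shown here, the exchange on the double-bonded nitrogen gives the first step that can be traced in this assay and shows that this position is not indifferent to the group it carries. With tert-butyl in place of 1,2-dimethylbutyl, the result is a 3.2-fold lower number from compound 2 to compound 3 (0.51 log units; beyond the scatter), so the shorter, fully branched group with 4 heavy atoms needs less compound for the effect than the chain with 6, a reading that rests on this single pair alone. No measurement shown accounts for this fall in dose.

Going by these compounds, whether the dose would change again with an ethyl or isopropyl group on this nitrogen, or with a cyclohexyl ring or a chain ending in a hydroxyl group, remains open. Also open, on these data alone, is whether the same exchange would give a step of similar size on the core of compound 1, whose result in this assay is only a limit of the assay.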